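Methylsulfonyl for Hydroxy at a Second Ring Position

The compounds below may be only part of what the source reports. "The series", "measured", "known", "first", "only" and "open" are said of these compounds alone.

Of the compounds shown here, three built on a shared core have been tested in an ADME assay on microsomes from liver (Homo sapiens) for metabolic stability, read by LC-MS, with a stated time of 30 min, tested at 0.5 uM; on this read-out higher numbers stand for a more stable compound and lower numbers for a less stable compound. Compound 1 `Oc1ccc(-c2nc(-c3csc(N=C4NCCCN4)n3)cs2)cc1` gives 86%. Compound 2 `Oc1cccc(-c2nc(-c3csc(N=C4NCCCN4)n3)cs2)c1` differs from compound 1 in one place, (3-hydroxyphenyl in place of 4-hydroxyphenyl on an aromatic carbon), and in this assay compound 2 gives 77%; the step is a number 9 percentage points lower from compound 1 to compound 2 (within the scatter). Compound 3 `CS(=O)(=O)c1ccc(-c2nc(-c3csc(N=C4NCCCN4)n3)cs2)cc1` is compound 1 with methylsulfonyl in place of hydroxy on an aromatic carbon, and in this assay compound 3 gives 87%, a step of a number 1 percentage points higher from compound 1 to compound 3 (within the scatter).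

Compound 4 `CS(=O)(=O)c1cccc(-c2nc(-c3csc(N=C4NCCCN4)n3)cs2)c1` has not yet been measured. It arises from compound 2 by the same kind of change, (methylsulfonyl in place of hydroxy on an aromatic carbon). The two changes are not identical: in compound 3 the new group sits para to a large group, in compound 4 it sits meta to a large group. Beside the earlier step, the step expected here is a number 3 percentage points higher from compound 2 to compound 4 (within the scatter), which rests on the step of a number 1 percentage points higher from compound 1 to compound 3 (within the scatter) seen for the same kind of change. On that basis compound 4 is estimated to give 80%, with a likely range from 68% to 92%.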

Compound 4, percent of the compound remaining: 85%
Beside the measured number, compound 4's estimate is 5 percentage points below it; measured number inside the range.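

In this assay, methylsulfonyl in place of hydroxy on an aromatic carbon gives a step of a number 8 percentage points higher from compound 2 to compound 4 (within the scatter). Set beside the same change on the core of compound 1, this step cannot be told apart from the earlier one: the same change on two cores in this assay, a number 1 percentage points higher (within the scatter) from compound 1 to compound 3 and a number 8 percentage points higher (within the scatter) from compound 2 to compound 4, 7 percentage points apart, within the scatter of two such steps

So, across these two pairs, the change carries over in a modest sense: on neither core does the step leave the usual scatter of the measurement, but two pairs cannot establish a rule for other cores in the series, and neither step shows that methylsulfonyl and hydroxy truly differ in this read-out.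

The compounds shown leave open whether an amine, a carboxylic acid or a longer chain at the same place on the six-membered aromatic ring would give numbers like these. They also leave open how the same change would behave if the shared core itself were altered elsewhere.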